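Growth inhibition series: hydroxymethyl for vinyl on a ring carbon

The source may hold more compounds than are shown below. What is called first, only, known or untested is meant among the compounds shown, and "the series" means these compounds.

Measured compounds:
- compound 1, `C=CC[C@@]12CCN[C@@H]1n1c3nc4ccc(OC)cc4cc3c(=O)c3cccc2c31` — 14800 nM
- compound 2, `COc1ccc2nc3c(cc2c1)c(=O)c1cccc2c1n3[C@H]1NCC[C@@]21CCO` — 1400 nM
- compound 3, `C=CC[C@@]12CCN(C(=O)OC(C)(C)C)[C@@H]1n1c3nc4ccc(O)c(CN(C)C)c4cc3c(=O)c3cccc2c31` — 35200 nM

All three were run in a functional assay on HeLa cells (Homo sapiens) for inhibition, read by trypan blue exclusion, with a stated time of 72 h; on this read-out lower numbers stand for stronger inhibition of growth and higher numbers for weaker inhibition of growth. Compound 1 gives 14800 nM in this assay, and compound 2 gives 1400 nM. The two differ by one change, (hydroxymethyl in place of vinyl on a saturated chain carbon bound to a saturated ring carbon), and the step it made is an 11-fold lower number from compound 1 to compound 2 (1.02 log units; beyond the scatter).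

Compound 3 gives 35200 nM in this assay, the highest number of the three. How its core differs from that of compound 1 is not broken down here: the two differ in more than one place.

Compound 4, `CN(C)Cc1c(O)ccc2nc3c(cc12)c(=O)c1cccc2c1n3[C@H]1N(C(=O)OC(C)(C)C)CC[C@@]21CCO`, has not been measured. It stands to compound 3 as compound 2 stands to compound 1: the change is hydroxymethyl in place of vinyl on a saturated chain carbon bound to a saturated ring carbon, and the place reads the same in both pairs, so it is the same kind of change on a different core.

For the measured compounds named here, only one earlier instance of this change is available, and it lies beyond the scatter, so the expectation for compound 4 rests on compound 3 with its value 35200 nM and on the step of an 11-fold lower number from compound 1 to compound 2 (1.02 log units; beyond the scatter) carried over without change. Some allowance is made for the different core, so the expected step is set a little smaller than the earlier one: the estimated step is an 8.8-fold lower number from compound 3 to compound 4 (0.94 log units; beyond the scatter). Compound 4 is accordingly expected to give about 4000 nM in this assay, with a plausible range from 1500 nM to 11000 nM.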

Compound 4, concentration for 50% growth inhibition: 13000 nM
Beside the measured number, compound 4's estimate is 3.3-fold (0.51 log units) below it; measured number above the stated range.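

In this assay, hydroxymethyl in place of vinyl gives a step in the same direction on the second core, with a 2.7-fold lower number from compound 3 to compound 4 (0.43 log units; beyond the scatter), so across these two pairs the direction of the change carries over from one core to the other. The size of the step does not carry over, and the two steps differ by more than repeated measurements would explain: the same change on two cores in this assay, an 11-fold lower number (1.02 log units; beyond the scatter) from compound 1 to compound 2 and a 2.7-fold lower number (0.43 log units; beyond the scatter) from compound 3 to compound 4, 3.9-fold (0.59 log units) apart, beyond the scatter of two such steps. For the compounds shown here, this rests on only two pairs, and since the core of compound 1 and the core of compound 3 differ in more than one place, the data do not show which of those differences goes with the smaller step, nor do they give a size to expect on any further core.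

Still open is which part of the difference between the two cores tracks with the size of the step, as no compound shown carries only part of that difference. Also open, going by these compounds, is how other groups would behave on the saturated chain carbon bound to a saturated ring carbon, for instance a carboxylic acid in place of the hydroxymethyl, or a longer chain ending in a hydroxyl group.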